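A few compounds are considered here, and "the series" means these few. Any claim that something is new, unique, unknown or untested is made for them only; others in the source may bear on it.

Of the compounds shown here, three share one core and have been tested in an ADME assay on Vero cells (Chlorocebus sabaeus) for cytotoxicity, read by MTT assay, with a stated time of 72 h; a higher number here means a weaker inhibitor, a lower number a stronger inhibitor. Compound 1 `Cn1cc([N+](=O)[O-])cc1-c1nnc(-c2cc3ccccc3[nH]2)o1` gives 109000 nM, compound 2 `Cn1cc([N+](=O)[O-])cc1-c1nnc(-c2ccccc2Br)o1` gives 303000 nM, and compound 3 `Cn1cc([N+](=O)[O-])cc1-c1nnc(-c2ccccc2OC(F)(F)F)o1` gives 308000 nM. Compound 2 stands second highest of the three: compound 3 is within the scatter of it, while compound 1 lies lower beyond the scatter. Going by the values given here, the only single-point step, a 1.0-fold higher number from compound 2 to compound 3 (0.01 log units; within the scatter), swaps one substituent on the same aromatic carbon. Compound 4 `Cn1cc([N+](=O)[O-])cc1-c1nnc(-c2ccc[nH]2)o1` differs from compound 2 by 1H-pyrrol-2-yl in place of 2-bromophenyl on an aromatic carbon. Among the compounds with values here, no measured step exchanges a whole ring, so the measured step bears only loosely here; the lower value of compound 1, which also carries a ring bearing a hydrogen-bond donor, suggests a modest drop. Compound 4 is therefore expected to give 160000 nM, between 60000 nM and 400000 nM, a step of a 1.9-fold lower number from compound 2 to compound 4 (0.28 log units; within the scatter) expected in this assay.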

Compound 4, half-maximal inhibitory concentration: 208000 nM
Compound 4: the middle estimate sits 1.3-fold (0.11 log units) below what was measured, and the stated range covers the measured number.
By their numbers in this assay, from the lowest: compounds 1, 4, 2 and 3 (each within the scatter of the next, the first and the last beyond it).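

Exchanging the whole ring at this position, not just a substituent on it, gives a 1.5-fold lower number from compound 2 to compound 4 (0.16 log units; within the scatter) in this assay. So 1H-pyrrol-2-yl, a five-membered ring that carries a hydrogen-bond donor, can stand in place of 2-bromophenyl on this aromatic carbon without moving the number outside the scatter. Nothing measured here offers an explanation for this result. As far as these compounds go, it remains open whether a non-ring group at this place, such as an amine or a carboxylic acid, would also stay within the scatter of compound 2.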